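The compounds below may be only part of what the source reports. "The series", "measured", "known", "first", "only" and "open" are said of these compounds alone.

Measured so far in a functional assay on MOLT-4 cells (Homo sapiens) for inhibition, read by sulforhodamine B assay, with a stated time of 48 h; on this read-out higher numbers stand for lower toxicity in this test and lower numbers for higher toxicity in this test:

Compound 1 `Nc1cc(N)c2nc(-c3ccccc3)c(Oc3ccc(Cl)c(Cl)c3)nc2c1` — the value for compound 1 is a limit of the assay, < 100000 nM.
Compound 2 `COc1cc(CNc2nc3cc(N)cc(N)c3nc2-c2ccccc2)cc(OC)c1OC` — the value for compound 2 is a limit too, < 50200 nM.
Compound 3 `CCOC(=O)[C@H](CCC(=O)O)NC(=O)c1ccc(Oc2nc3cc(N)cc(N)c3nc2-c2ccccc2)cc1` — the value for compound 3 is also a limit, < 100000 nM.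

Compound 1 stands on a limit only, and it is not alone in this: two further values in the series are limits as well, as the limit of < 100000 nM in this assay, at which 2 of the 3 values shown sit, and the limit of < 50200 nM in this assay, at which 1 of the 3 values shown sits, show, so no ordering among the three is possible.

Compound 4 `Nc1cc(N)c2nc(-c3ccccc3)c(NCc3ccc(F)cc3)nc2c1` is not yet measured. It differs from compound 1 by (4-fluorobenzyl)amino in place of 3,4-dichlorophenoxy on an aromatic carbon. No step between two measured compounds exists in this set, so no size of change is known from which to reason. The expectation is for a step from compound 1 to compound 4 of a step that the limit leaves unreadable from compound 1 to compound 4, that is, nothing beyond the scatter that can be told from the numbers at hand. Compound 4 is estimated at 30000 nM, within 5000 nM to 100000 nM, with a fair chance that this assay again reports only a limit.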

Compound 4, concentration lethal to 50% of the cells: < 100000 nM
Compound 4 ended at the assay's limit; the forecaster's own chance of this, stated with the estimate: 60%; the middle value lies beyond the limit too.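

Compound 1 and compound 4 both rest on the same limit, so no step between them can be read: the limit of < 100000 nM in this assay, at which 3 of the 4 values shown sit.

The compounds shown leave open whether (4-fluorobenzyl)amino and 3,4-dichlorophenoxy differ at all in this assay, and no value shown gives an actual number.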